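The source may hold more compounds than are shown below. What is called first, only, known or untested is meant among the compounds shown, and "the series" means these compounds.

In an ADME assay on HepG2 cells (Homo sapiens) for inhibition, read by fluorescence and resazurin assay, with a stated time of 72 h (a lower number here means a stronger inhibitor, a higher number a weaker inhibitor), compound 1 `Cc1cccc(Nc2nccc(Nc3ccc4cn[nH]c4c3)n2)c1` gives 15000 nM, compound 2 `NC(=O)c1ccc(Nc2nccc(Nc3ccc4cn[nH]c4c3)n2)cc1` gives 16000 nM and compound 3 `Brc1ccc(Nc2nccc(Nc3ccc4cn[nH]c4c3)n2)cc1` gives 20000 nM. Compound 3 cannot be told apart from the other two on these numbers. Compound 4 `Brc1cccc(Nc2nccc(Nc3ccc4cn[nH]c4c3)n2)c1` has the same atoms joined differently: 3-bromophenyl in place of 4-bromophenyl on a nitrogen on an aromatic ring. This places 3-bromophenyl in place of 4-bromophenyl on a nitrogen on an aromatic ring. Among the measured compounds shown here, no measured step makes this exact swap, but two come close: a 1.3-fold higher number from compound 1 to compound 3 (0.12 log units; within the scatter), which changes the group at that same place, and a 1.3-fold higher number from compound 2 to compound 3 (0.10 log units; within the scatter), which replaces bromo with carbamoyl. Both stay within the scatter, so no step beyond the scatter is expected here. The expected change is a 1.2-fold lower number from compound 3 to compound 4 (0.07 log units; within the scatter). In this assay the estimate for compound 4 is 17000 nM, with an expected range of 9000 nM to 32000 nM.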

Compound 4, half-maximal inhibitory concentration: 17000 nM
For compound 4 middle estimate and measured number coincide at the digits printed; the range from low to high includes it.
By their numbers in this assay, from the lowest: compounds 1, 2, 4 and 3 (each within the scatter of the next).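

Placing the bromo group as 3-bromophenyl rather than 4-bromophenyl gives a 1.2-fold lower number from compound 3 to compound 4 (0.07 log units; within the scatter) in this assay, so these two arrangements of the same atoms cannot be told apart here. Bromo in place of methyl gives a 1.1-fold higher number from compound 1 to compound 4 (0.05 log units; within the scatter), so that swap also leaves the number within the scatter. No measurement is available that bears on these results. On these data alone, whether an amine or a carboxylic acid on this phenyl ring would move the number beyond the scatter remains open. So does the effect of any change to the shared core.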